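The compounds below may be only part of what the source reports. "The series", "measured", "known", "first", "only" and "open" are said of these compounds alone.

Among the three compounds measured in a functional assay for agonist activity at G protein-coupled receptor 88 (Homo sapiens), read by HTRF and cAMP accumulation (on this read-out lower numbers stand for an effect already at smaller amounts and higher numbers for an effect only at larger amounts of compound), compound 3 `CC[C@H](C)[C@H](N)CN(C(=O)[C@@H]1C[C@H]1c1ccccc1)c1ccc(-c2ccc(COC(C)(C)C)cc2)cc1` gives 280 nM, the highest number of the set. Compound 1 `CCCc1ccc(-c2ccc(N(C[C@@H](N)[C@@H](C)CC)C(=O)[C@@H]3C[C@H]3c3ccccc3)cc2)cc1` gives 61 nM and compound 2 `CC[C@H](C)[C@H](N)CN(C(=O)[C@@H]1C[C@H]1c1ccccc1)c1ccc(-c2ccc(OC)cc2)cc1` gives 120 nM. The step of a 4.6-fold higher number from compound 1 to compound 3 (0.66 log units; beyond the scatter) and the step of a 2.3-fold higher number from compound 2 to compound 3 (0.37 log units; beyond the scatter) show that the chain carrying tert-butoxy reads higher than either the propyl or the methoxy substituent, whereas a 2.0-fold higher number from compound 1 to compound 2 (0.29 log units; within the scatter). Compound 4 `CC[C@H](C)[C@H](N)CN(C(=O)[C@@H]1C[C@H]1c1ccccc1)c1ccc(-c2ccc(CNC)cc2)cc1` differs from compound 3 in one place: methylamino in place of tert-butoxy on a saturated chain carbon bound to an aromatic carbon. Among the measured compounds shown here, no measured step places a methylamino group at this position, so the two steps leading into compound 3 are the only guide; both say that the tert-butoxy chain carries the highest number of the set, and its exchange for a smaller group is expected to bring the number back toward the region occupied by compound 1 and compound 2. Compound 4 is therefore expected to show a 2.5-fold lower number from compound 3 to compound 4 (0.41 log units; beyond the scatter), with an estimate of 110 nM and a range from 40 nM to 300 nM.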

Compound 4, half-maximal effective concentration: 6400 nM
Beside the measured number, compound 4's estimate is 58-fold (1.76 log units) below it, outside the stated range (above it).
By their numbers in this assay, from the lowest: compounds 1 and 2 (each within the scatter of the next); then compound 3; then compound 4.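

In this assay, among the compounds shown here, the place on a saturated chain carbon bound to an aromatic carbon proves far less tolerant than the earlier compounds suggested, with methylamino in place of tert-butoxy giving a large step (a 23-fold higher number from compound 3 to compound 4 (1.36 log units; beyond the scatter)). The earlier substituents stayed within modest steps of one another, while the (methylamino)methyl group stands well apart from both methoxy (a 53-fold higher number from compound 2 to compound 4 (1.73 log units; beyond the scatter)) and the propyl chain of the first compound, where methylamino replaces ethyl (a 100-fold higher number from compound 1 to compound 4 (2.02 log units; beyond the scatter)). Nothing available here explains a change of this size.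

From the compounds shown here alone, whether the rise follows the nitrogen itself or the amine hydrogen remains open. A dimethylamino group or a methoxymethyl group on this aromatic carbon would separate the two, and a longer chain carrying the amine would show whether its distance from the aromatic carbon matters.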